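The compounds below may be only part of what the source reports. "The series", "measured", "known", "first", "only" and "open" are said of these compounds alone.

Of the compounds shown here, two have been measured in an assay on isolated protein for displacement of a labelled ligand from sodium-dependent dopamine transporter (Homo sapiens); a lower number here means a stronger inhibitor, a higher number a weaker inhibitor. Compound 1 `CN(C)CC1C2CCC(C2)C1c1cccc2ccccc12` gives 430 nM, and compound 2 `COc1ccc2cc([C@H]3C4CCC(C4)[C@@H]3CN(C)C)ccc2c1` gives 64 nM, the lower of the two numbers, with a gap between them that lies beyond the usual scatter. Compound 3 `CNC[C@H]1C2CCC(C2)[C@@H]1c1ccc2cc(OC)ccc2c1` remains unmeasured. It differs from compound 2 by hydrogen in place of methyl on an amine nitrogen. Within the data shown here, no measured pair shows such a step, so the expected step in this assay, a 1.3-fold lower number from compound 2 to compound 3 (0.11 log units; within the scatter), is estimated to be small and not clearly beyond the scatter in either direction. Compound 3 is therefore estimated at 50 nM, within a likely range from 15 nM to 160 nM.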

Compound 3, inhibition constant: 60 nM
For compound 3 the middle estimate is 1.2-fold (0.08 log units) below the measured one; low and high end bracket the measured number.
By their numbers in this assay, from the lowest: compounds 3 and 2 (each within the scatter of the next); then compound 1.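

The swap of dimethylamino to methylamino gives a 1.1-fold lower number from compound 2 to compound 3 (0.03 log units; within the scatter) in this assay, so on this amine nitrogen one methyl can give way to hydrogen with no change that stands clear of the scatter. Among these compounds, this is the first measured pair that differs in one place, and so the first direct reading of this position. Nothing at hand explains the result.

Still open, on these data alone, is whether a primary amine, with hydrogen in place of both methyls, would read the same. As far as these compounds go, an ethyl group on this nitrogen, or a pyrrolidine ring built around it, is equally open.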